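Saturating a linker chain in two tetrahydroquinoline-derived amides

A few compounds are considered here, and "the series" means these few. Any claim that something is new, unique, unknown or untested is made for them only; others in the source may bear on it.

Compound 1 `COC(=O)CCCNC(=O)c1cccc2c1NCCC2` in an ADME assay on HeLa cells (Homo sapiens) for cytotoxicity (on this read-out lower numbers stand for higher toxicity in this test and higher numbers for lower toxicity in this test), gives > 30000 nM, which is a limit of the test and not a number.
Compound 2 `COC(=O)/C=C/CNC(=O)c1cccc2c1NCCC2` in this assay gives > 30000 nM, again a limit.
Compound 3 `COC(=O)/C=C/CNC(=O)c1cccc2c1NC(C)(C)C=C2C` in this assay gives > 30000 nM, also a limit.

Compound 1 and compound 2 share one core; compound 3 carries another, and the difference between the two cores is not broken down here. From compound 2 to compound 1 the change is 2-(methoxycarbonyl)ethyl in place of 2-(methoxycarbonyl)ethenyl on a saturated chain carbon bound to an amide-type nitrogen, and the step is a step that the two limits leave unreadable from compound 2 to compound 1. Compound 4 `COC(=O)CCCNC(=O)c1cccc2c1NC(C)(C)C=C2C`, not yet measured, is made from compound 3 by the same change, (2-(methoxycarbonyl)ethyl in place of 2-(methoxycarbonyl)ethenyl on a saturated chain carbon bound to an amide-type nitrogen). Because (the limit of > 30000 nM in this assay, at which 3 of the 3 values shown sit), nothing here reads as a size. Compound 4 is therefore expected to sit at the limit as well, with the estimated step being a step that the limit leaves unreadable from compound 3 to compound 4. For compound 4 the estimate is 45000 nM, from 20000 nM to 150000 nM.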

Compound 4, half-maximal cytotoxic concentration: > 30000 nM
Compound 4: only a limit was reported; the forecaster's own chance of this, stated with the estimate: 85%; the middle value lies beyond the limit too.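

No step can be read from compound 3 to compound 4, since both results are limits of the test and not numbers: the limit of > 30000 nM in this assay, at which 4 of the 4 values shown sit.

The compounds shown leave open whether 2-(methoxycarbonyl)ethyl in place of 2-(methoxycarbonyl)ethenyl changes the read-out at all in this assay.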